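Carbinol anilide series: tolerance in cells, step to compound 3

A few compounds are considered here, and "the series" means these few. Any claim that something is new, unique, unknown or untested is made for them only; others in the source may bear on it.

Measured so far:
compound 1 `CCCC(=O)N(C)c1ccc(C(O)(C(F)(F)F)C(F)(F)F)cc1`: > 100000 nM
compound 2 `O=C(c1ccccc1)N(Cc1ccccc1)c1ccc(C(O)(C(F)(F)F)C(F)(F)F)cc1`: 7500 nM

In an ADME assay on Li23 cells (Homo sapiens) for cytotoxicity, read by WST assay (a higher number here means that more compound is tolerated, a lower number that less compound is tolerated), compound 1 gives > 100000 nM, which is a limit of the assay and not a number. Compound 1 therefore sits at the limit of > 100000 nM in this assay, at which 1 of the 2 values shown sits, so only a range is known for it, at the tolerated end of what has been seen. In this assay compound 2 gives 7500 nM, a number rather than a limit. Within the data shown here, no step between measured compounds that differ in a single place is available, so nothing measured ties compound 1 to compound 2 directly.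

Compound 3 `CN(c1ccc(C(O)(C(F)(F)F)C(F)(F)F)cc1)S(=O)(=O)c1ccccc1` is the next one to be measured in this assay. It differs from compound 1 by phenylsulfonyl in place of propylcarbonyl on a nitrogen on an aromatic ring. Among the measured compounds shown here, no measured step covers this change; the move from compound 1 toward a compound carrying a second aromatic ring on the nitrogen is expected to lower the tolerated concentration beyond the scatter, and the step from compound 1 to compound 3 is expected to be an at least 2.5-fold lower number from compound 1 to compound 3 (0.39 log units; beyond the scatter). Compound 3 is estimated at 40000 nM, with a range from 12000 nM to 100000 nM.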

Compound 3, half-maximal cytotoxic concentration: 16000 nM
Compound 3: the middle estimate sits 2.5-fold (0.40 log units) above what was measured, within the range that was stated.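

In this assay the nitrogen on an aromatic ring now has its first step in a single place, where phenylsulfonyl in place of propylcarbonyl gives an at least 6.2-fold lower number from compound 1 to compound 3 (0.79 log units; beyond the scatter) with the rest of the core of compound 1 unchanged. As far as these compounds go, compound 1 stands at a limit of the assay and not at a number, so this step is a lower bound and its true size is unknown: the limit of > 100000 nM in this assay, at which 1 of the 3 values shown sits. Compound 3 gives 16000 nM, a number, so the group on this nitrogen can by itself move the tolerated concentration beyond the scatter, something compound 2 could not show, as it differs from compound 1 in more than one place.

The change swaps the chain for an aromatic ring and the carbonyl for a sulfonyl in one move, and the compounds shown cannot tell which of the two carries the step. A propylsulfonyl group on the same nitrogen, or an amine or a carboxylic acid on the phenyl ring of phenylsulfonyl, would remain to be read against compound 3 in this assay.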